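Urea series: trifluoromethyl to chloro on the distal ring

This account rests on a few compounds, and the source may have more. Where it says the series, first, only, none or still open, it means among the compounds named here.

Two compounds of the shared core are in hand. Compound 1 `COc1cc2cc(Oc3ccc(NC(=O)Nc4cccc(C(F)(F)F)c4)cc3)c(C)nc2cc1OC` gives 2040 nM in a functional assay on OVCAR-3 cells (Homo sapiens) for inhibition, read by sulforhodamine B assay, with a stated time of 48 h (on this read-out lower numbers stand for stronger inhibition of growth and higher numbers for weaker inhibition of growth), and compound 2 `COc1cc2cc(Oc3ccc(NC(=O)Nc4ccc(Cl)c(C(F)(F)F)c4)cc3)c(C)nc2cc1OC` gives 1160 nM. Compound 2 sits alongside compound 1, since the step of a 1.8-fold lower number from compound 1 to compound 2 (0.25 log units; within the scatter) lies within the scatter. Compound 3 `COc1cc2cc(Oc3ccc(NC(=O)Nc4ccc(Cl)c(Cl)c4)cc3)c(C)nc2cc1OC` differs from compound 2 by chloro in place of trifluoromethyl on an aromatic carbon. Among the measured compounds shown here, no measured step covers this swap; the only step in hand, a 1.8-fold lower number from compound 1 to compound 2 (0.25 log units; within the scatter), bears on the neighbouring chloro and was small. A step within the scatter is therefore expected, with a 1.4-fold higher number from compound 2 to compound 3 (0.14 log units; within the scatter) as the working guess. Compound 3 is expected to give 1600 nM, between 600 nM and 4500 nM.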

Compound 3, concentration for 50% growth inhibition: 2340 nM
The estimate for compound 3 lay 1.5-fold (0.17 log units) below the measured number; low and high end bracket the measured number.
By their numbers in this assay, from the lowest: compounds 2, 1 and 3 (each within the scatter of the next).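

At this aromatic carbon, ortho to a chloro group, chloro in place of trifluoromethyl gives a 2.0-fold higher number from compound 2 to compound 3 (0.30 log units; within the scatter) in this assay, so trifluoromethyl and chloro are not told apart here. Taking 3,4-dichlorophenyl in place of 3-(trifluoromethyl)phenyl gives a 1.1-fold higher number from compound 1 to compound 3 (0.06 log units; within the scatter), so all three compounds now sit together on this read-out. No evidence is available that bears on these results.

Going by these compounds, whether a nitrile, a methoxy or an amine at this carbon would give a step beyond the scatter remains open. Also open, on these data alone, is how hydrogen at this carbon would read with the chloro group kept.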